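Nitro in place of chloro on the aryl group of compound 3

The source may hold more compounds than are shown below. What is called first, only, known or untested is meant among the compounds shown, and "the series" means these compounds.

In an assay for binding affinity to adenosine receptor A1 (Bos taurus) (a higher number here means a weaker inhibitor, a lower number a stronger inhibitor), the series spans compound 1 `Cn1c(=O)c2nc(-c3ccc(Cl)cc3)[nH]c2n(C)c1=O` with 0.8 nM, compound 2 `Cc1cccc(-c2nc3c(=O)n(C)c(=O)n(C)c3[nH]2)c1` with 13 nM, and compound 3 `Cn1c(=O)c2nc(-c3ccc(Cl)cc3N)[nH]c2n(C)c1=O` with 0.35 nM. Compound 3 holds the lowest of the three numbers; the nearest number belongs to compound 1, the furthest to compound 2. Among the measured compounds shown here, the only single-place step recorded within these three is a 2.3-fold lower number from compound 1 to compound 3 (0.36 log units; beyond the scatter), an amino in place of hydrogen on an aromatic carbon, and it lies beyond the scatter though it remains modest.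

Compound 4 `Cn1c(=O)c2nc(-c3ccc([N+](=O)[O-])cc3N)[nH]c2n(C)c1=O` differs from compound 3 in one place: nitro in place of chloro on an aromatic carbon. For the measured compounds named here, no measured step exchanges the chloro itself. The step of a 2.3-fold lower number from compound 1 to compound 3 (0.36 log units; beyond the scatter) concerns the amino group, which stays in place from compound 3 to compound 4, and compound 2 differs from the others in more than one place, so it offers no single-place comparison for the chloro. The bearing of the known step on the present change is therefore indirect at best.

Going by the values given here, with no direct precedent, the step of a 2.0-fold higher number from compound 3 to compound 4 (0.30 log units; within the scatter) is expected to be small, within or near the scatter, in either direction. For compound 4 the estimated value is 0.7 nM, with a range from 0.25 nM to 2 nM.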

Compound 4, half-maximal inhibitory concentration: 2.5 nM
Estimate against measurement, compound 4: 3.6-fold (0.55 log units) below; the measured number lies above the stated range.
By their numbers in this assay, from the lowest: compound 3; then compound 1; then compound 4; then compound 2.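

In this assay, among the compounds shown here, this is the first measured exchange of the chloro group itself, and a 7.1-fold higher number from compound 3 to compound 4 (0.85 log units; beyond the scatter) shows that the group on the aromatic carbon para to a large group matters to the number, since the step lies beyond the scatter. The two single-place steps recorded on this aryl group run in opposite directions: a 2.3-fold lower number from compound 1 to compound 3 (0.36 log units; beyond the scatter) comes with the amino group, while the new step comes with nitro in place of chloro, and the amino group is present on both sides of the new step. Even so, compound 4 remains at 2.5 nM, so this place accepts the larger nitro group without the number leaving the nanomolar range, although nothing measured here bears on why the number rises with this exchange.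

Still open is whether the same exchange gives a step of similar size on the aryl group without the amino group, as the compounds shown include no nitro counterpart of compound 1. Also open, as far as these compounds go, is how other groups at this place compare with chloro and nitro, such as a methoxy group, a carboxylic acid, an amine or a longer alkyl chain, and whether the rise follows nitro alone or extends to them.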